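A Fluoro Analogue of Compound 1 Awaits Measurement

The compounds below may be only part of what the source reports. "The series", "measured", "known", "first", "only" and "open" are said of these compounds alone.

The parent of this small series is compound 1 `CC1=C(/C=C/C(=O)/C=C/c2ccccc2)C(C)(C)CCC1`. In a functional assay on MCF7 cells (Homo sapiens) for cytotoxicity, read by sulforhodamine B assay, with a stated time of 48 h (on this read-out higher numbers stand for weaker inhibition and lower numbers for stronger inhibition), compound 1 gives 10600 nM, the lowest of the three numbers recorded so far. Compound 2 `CC1=C(/C=C/C(=O)/C=C/c2ccccc2Cl)C(C)(C)CCC1` carries chloro in place of hydrogen on an aromatic carbon and in this assay compound 2 gives 54600 nM. Compound 3 `CC1=C(/C=C/C(=O)/C=C/c2ccccc2Br)C(C)(C)CCC1` carries bromo at the same place, and in this assay compound 3 gives 20700 nM. The step of a 5.2-fold higher number from compound 1 to compound 2 (0.71 log units; beyond the scatter) lies beyond the scatter, while a 2.0-fold higher number from compound 1 to compound 3 (0.29 log units; within the scatter) does not; between the two halogenated compounds a 2.6-fold lower number from compound 2 to compound 3 (0.42 log units; beyond the scatter).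

Compound 4 `CC1=C(/C=C/C(=O)/C=C/c2ccccc2F)C(C)(C)CCC1` has not been measured. It differs from compound 1 by fluoro in place of hydrogen on an aromatic carbon. The two measured steps that bear on this change are the chloro and bromo substitutions at the same place, one modest and one within the scatter, and both went toward higher numbers. A third halogen at that place is therefore expected to give a small step in this assay, in the direction of a higher number, quite possibly within the scatter. Compound 4 is expected to give 15000 nM, with a range from 6000 nM to 40000 nM. This estimate means an expected step of a 1.4-fold higher number from compound 1 to compound 4 (0.15 log units; within the scatter).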

Compound 4, half-maximal inhibitory concentration: 11000 nM
Beside the measured number, compound 4's estimate is 1.4-fold (0.13 log units) above it; low and high end bracket the measured number.
By their numbers in this assay, from the lowest: compounds 1, 4 and 3 (each within the scatter of the next); then compound 2.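

In this assay the fluoro change gives a 1.0-fold higher number from compound 1 to compound 4 (0.02 log units; within the scatter) and so moves the number no further than the scatter, which shows that this aromatic carbon can carry a small halogen with no readable change from the parent. Bromo at this place also stays within the scatter of compound 1, so compound 2 is the one halogenated compound here that stands apart from the parent, and the new compound confirms this gap with a 5.0-fold lower number from compound 2 to compound 4 (0.70 log units; beyond the scatter) while a 1.9-fold lower number from compound 3 to compound 4 (0.27 log units; within the scatter) leaves the fluoro and bromo compounds unseparated; the series therefore does not climb steadily through the three halogens, and compound 2, with the chloro group, is the weakest of the four. Nothing available here accounts for why the chloro compound stands apart from the other three.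

The compounds shown carry only hydrogen or a halogen at this place, so it remains open what an amine, a methoxy group or a carboxylic acid would do there. As far as these compounds go, it also remains open whether the chloro result would recur with the same group on another carbon of the ring.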